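One Halogen Swap, Measured Once and Expected Again

The source may hold more compounds than are shown below. What is called first, only, known or untested is meant among the compounds shown, and "the series" means these compounds.

Of the compounds shown here, three built on a shared core have been tested in a functional assay on HCT-116 cells (Homo sapiens) for cytotoxicity, read by MTT assay, with a stated time of 72 h; a lower number here means a stronger inhibitor, a higher number a weaker inhibitor. Compound 1 `CCC/C(=C\c1cc(OC)c(OC)c(OC)c1)C(=O)N1CCC=C(Br)C1=O` gives 2140 nM in this assay. Compound 3 `CCC/C(=C\c1cc(OC)c(OC)c(OC)c1)C(=O)N1CCC=C(Cl)C1=O` gives 8080 nM in this assay. Compound 2 `CC/C(=C\c1cc(OC)c(OC)c(OC)c1)C(=O)N1CCC=C(Cl)C1=O` gives 9170 nM in this assay, the highest of the three numbers, although its gap to compound 3 lies within the scatter.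

Two single changes link these compounds. Compound 1 differs from compound 3 in one place bromo in place of chloro on a double-bonded ring carbon and that change brought a 3.8-fold lower number from compound 3 to compound 1 (0.58 log units; beyond the scatter). Compound 3 differs from compound 2 in one place hydrogen in place of methyl on a saturated chain carbon, two bonds along the chain from a double-bonded chain carbon and here the step was a 1.1-fold lower number from compound 2 to compound 3 (0.05 log units; within the scatter), so the two cores are not told apart by this assay.

Compound 4 `CC/C(=C\c1cc(OC)c(OC)c(OC)c1)C(=O)N1CCC=C(Br)C1=O` has not yet been measured in this assay. It differs from compound 2 in one place (bromo in place of chloro on a double-bonded ring carbon). The place of this change is described in the same words as the change from compound 3 to compound 1, so it is the same change, made on the core of compound 2 rather than the core of compound 3. Going by the values given here, since the two cores stand within the scatter of each other, the earlier step is the only guide. Among the compounds with values here, the step from compound 2 to compound 4 in this assay is expected to be about a 3.7-fold lower number from compound 2 to compound 4 (0.56 log units; beyond the scatter), resting on the single observed step of a 3.8-fold lower number from compound 3 to compound 1 (0.58 log units; beyond the scatter). Compound 4 is therefore estimated at 2500 nM in this assay, with an expected range from 1100 nM to 6000 nM.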

Compound 4, half-maximal inhibitory concentration: 3020 nM
Beside the measured number, compound 4's estimate is 1.2-fold (0.08 log units) below it, and the stated range covers the measured number.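

In this assay, bromo in place of chloro on a double-bonded ring carbon gave a 3.0-fold lower number from compound 2 to compound 4 (0.48 log units; beyond the scatter), and this step on the core of compound 2 matches the one on the core of compound 3: the same change on two cores in this assay, a 3.8-fold lower number (0.58 log units; beyond the scatter) from compound 3 to compound 1 and a 3.0-fold lower number (0.48 log units; beyond the scatter) from compound 2 to compound 4, 1.2-fold (0.09 log units) apart, within the scatter of two such steps. The other single change, on the saturated chain carbon, gave a 1.4-fold higher number from compound 1 to compound 4 (0.15 log units; within the scatter), so the two cores stay within the scatter of each other with bromo as they did with chloro: the same change on two cores in this assay, a 1.1-fold lower number (0.05 log units; within the scatter) from compound 2 to compound 3 and a 1.4-fold lower number (0.15 log units; within the scatter) from compound 4 to compound 1, 1.2-fold (0.09 log units) apart, within the scatter of two such steps. Going by these compounds alone, this shows that the halogen swap carried across these two closely related cores with its size intact, but it rests on only two pairs in one cell assay, so it does not show that the step would hold on a core that differs more, nor does it say why bromo and chloro differ.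

The compounds shown leave open whether fluoro or iodo on that double-bonded ring carbon would extend the step seen from chloro to bromo, and what an amine in that place would do. They also leave open whether a longer chain on the shared core would stay within the scatter as the two chains shown do.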